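Swapping cyclopentyl for cyclohexyl on a chloroacetyl urea

A few compounds are considered here, and "the series" means these few. Any claim that something is new, unique, unknown or untested is made for them only; others in the source may bear on it.

Compound 1 `c1cc2c(cc1NC1=NCCO1)CCC2`: 9100 nM
Compound 2 `c1cc(NC2=NCCO2)cc(OC2CCCCC2)c1`: 15900 nM
Compound 3 `O=C(CCl)NC(=O)Nc1cccc(OC2CCCC2)c1`: 6200 nM

In a functional assay on MCF7 cells (Homo sapiens) for inhibition, read by sulforhodamine B assay, with a stated time of 48 h (a lower number here means a stronger inhibitor of growth, a higher number a weaker inhibitor of growth), compound 3 gives 6200 nM. That number lies within the scatter of compound 1 and beyond the scatter below compound 2. Compound 4 `O=C(CCl)NC(=O)Nc1cccc(OC2CCCCC2)c1` differs from compound 3 in one place, with cyclohexyl in place of cyclopentyl on an oxygen on an aromatic ring. Among the compounds with values here, no measured pair shows this change, so the expectation rests on compound 3 alone. The expected 1.0-fold higher number from compound 3 to compound 4 (0.02 log units; within the scatter) is small, with no shift in either direction beyond the scatter. For compound 4 the estimate is 6500 nM, with an expected range of 3000 nM to 13000 nM.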

Compound 4, concentration for 50% growth inhibition: 6300 nM
Beside the measured number, compound 4's estimate is 1.0-fold (0.01 log units) above it; the measured number falls inside the stated range.
By their numbers in this assay, from the lowest: compounds 3, 4, 1 and 2 (each within the scatter of the next, the first and the last beyond it).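

In this assay, the ring on the oxygen can change from cyclopentyl to cyclohexyl with no real effect: a 1.0-fold higher number from compound 3 to compound 4 (0.01 log units; within the scatter). The group on the nitrogen does move the number, since the chloroacetyl urea in place of the ring of compound 2 gives a 2.5-fold lower number from compound 2 to compound 4 (0.40 log units; beyond the scatter). Nothing available explains either result.

Going by these compounds, whether the oxygen also accepts a very different group, such as a phenyl or a longer chain carrying an amine, stays open. So does whether the chlorine of the chloroacetyl urea plays any part in the step on the nitrogen.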